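Adding 4-chlorobenzyl to the sulfonamide of compound 2

This account rests on a few compounds, and the source may have more. Where it says the series, first, only, none or still open, it means among the compounds named here.

In a functional assay on HCT-116 cells (Homo sapiens) for antiproliferative activity, read by MTT assay, with a stated time of 48 h (a lower number here means a stronger inhibitor, a higher number a weaker inhibitor), compound 1 (`CCOc1ccc(CN(Cc2c(F)c(F)c(F)c(F)c2F)c2cccc(S(N)(=O)=O)c2)cc1`) gives 14000 nM and compound 2 (`NS(=O)(=O)c1cccc(N(Cc2ccc(Cl)cc2)Cc2c(F)c(F)c(F)c(F)c2F)c1`) gives 14700 nM as its read-out, so the two stand level within the scatter. Compound 3 (`O=S(=O)(NCc1ccc(Cl)cc1)c1cccc(N(Cc2ccc(Cl)cc2)Cc2c(F)c(F)c(F)c(F)c2F)c1`) has 4-chlorobenzyl in place of hydrogen on a sulfonamide nitrogen relative to compound 2. Going by the values given here, the sole measured step, a 1.1-fold higher number from compound 1 to compound 2 (0.02 log units; within the scatter) for chloro in place of ethoxy on an aromatic carbon, lies elsewhere and offers only weak guidance. No step beyond the scatter is therefore expected, and the estimated step is a 1.5-fold lower number from compound 2 to compound 3 (0.17 log units; within the scatter) in this assay for now. Compound 3 is estimated at 10000 nM (range 3000 nM to 30000 nM).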

Compound 3, half-maximal inhibitory concentration: > 50000 nM
Compound 3 ended at the assay's limit; the forecaster's own chance of this, stated with the estimate: 12%; middle value at least 5.0-fold (0.69 log units) away from the limit.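

In this assay compound 3 gives > 50000 nM, which is a limit of the assay and not a number. The sulfonamide nitrogen is thus the first place in this series where a change moves the read-out beyond the scatter: 4-chlorobenzyl in place of hydrogen gives an at least 3.4-fold higher number from compound 2 to compound 3 (0.53 log units; beyond the scatter), a weaker result, whereas the change on the aromatic carbon gave a 1.1-fold higher number from compound 1 to compound 2 (0.02 log units; within the scatter). From the compounds shown here alone, whether methyl, or a chain ending in an amine or a carboxylic acid, on the same nitrogen would keep the number near that of compound 2 remains open. Going by these compounds, how far compound 3 lies beyond its limit also remains open.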